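The source may hold more compounds than are shown below. What is called first, only, known or untested is meant among the compounds shown, and "the series" means these compounds.

Measured so far in an ADME assay on LLC-MK2 cells (Macaca mulatta) for cytotoxicity, read by spectrophotometry and crystal violet staining, with a stated time of 4 days; a lower number here means that less compound is tolerated, a higher number that more compound is tolerated:
compound 1 `CC(C)n1ncc2c(C(=O)Nc3cccc(F)c3)cc(-c3cccs3)nc21`, > 200000 nM, which is a limit of the assay and not a number
compound 2 `CC(C)n1ncc2c(C(=O)N3CCc4cccnc43)cc(-c3cccs3)nc21`, 50000 nM
compound 3 `CC(C)n1ncc2c(C(=O)Nc3ccncn3)cc(-c3cccs3)nc21`, 50000 nM

Compound 3 stands level with compound 2 in this assay, as the step of no change at the digits printed from compound 2 to compound 3 (within the scatter) shows. Only compound 1 sits at the limit (the limit of > 200000 nM in this assay, at which 1 of the 3 values shown sits). The step of an at least 4.0-fold lower number from compound 1 to compound 3 (0.60 log units; beyond the scatter) lowers the number on going to the pyrimidin-4-yl, and the step of an at least 4.0-fold lower number from compound 1 to compound 2 (0.60 log units; beyond the scatter) does the same with a different group on the carbonyl carbon.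

Compound 4 `CC(C)n1ncc2c(C(=O)Nc3cc(F)ccc3F)cc(-c3cccs3)nc21` differs from compound 3 by 2,5-difluorophenyl in place of pyrimidin-4-yl on an amide-type nitrogen. This brings back a fluorinated phenyl on the amide-type nitrogen, akin to the 3-fluorophenyl of compound 1, so the change runs opposite to the step of an at least 4.0-fold lower number from compound 1 to compound 3 (0.60 log units; beyond the scatter). For compound 4 a higher number in this assay is therefore expected, roughly a 3.0-fold higher number from compound 3 to compound 4 (0.48 log units; beyond the scatter), with a fair chance that only a limit is reported again. The estimate for compound 4 is 150000 nM, between 40000 nM and 300000 nM.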

Compound 4, half-maximal cytotoxic concentration: 100000 nM
Estimate against measurement, compound 4: 1.5-fold (0.18 log units) above; low and high end bracket the measured number.
By their numbers in this assay, from the lowest: compounds 2, 3 and 4 (each within the scatter of the next). At a limit, above all of these: compound 1.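

In this assay, 2,5-difluorophenyl in place of pyrimidin-4-yl on the amide-type nitrogen gives a 2.0-fold higher number from compound 3 to compound 4 (0.30 log units; within the scatter), and the change on the carbonyl carbon gives a 2.0-fold higher number from compound 2 to compound 4 (0.30 log units; within the scatter), so a fluorinated phenyl at this position is not separated from either of those groups. Fluoro in place of hydrogen on an aromatic carbon gives an at least 2.0-fold lower number from compound 1 to compound 4 (0.30 log units; that floor lies within the scatter), and this floor cannot show whether the added fluoro matters. Compound 1 is reported only as a limit of the assay, not as a number: the limit of > 200000 nM in this assay, at which 1 of the 4 values shown sits.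

Going by these compounds, whether compound 1 truly stands apart from compound 4 therefore stays open. Also open, on these data alone, is how a phenyl carrying a methoxy group or a carboxylic acid in place of fluoro would read in this assay.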